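A few compounds are considered here, and "the series" means these few. Any claim that something is new, unique, unknown or untested is made for them only; others in the source may bear on it.

Compound 1 `C=CCOc1ccc2c(=O)c(-c3cc(OC)c(OC)cc3OC)coc2c1` gives 6600 nM in a functional assay on HCT-116 cells (Homo sapiens) for antiproliferative activity, read by MTT assay, with a stated time of 24 h (on this read-out lower numbers stand for stronger inhibition and higher numbers for weaker inhibition), the highest of the two numbers recorded so far, though its nearest neighbour, compound 2 `COc1cc(OC)c(-c2coc3cc(OCc4ccccc4C(F)(F)F)ccc3c2=O)cc1OC`, gives 4760 nM, and the step of a 1.4-fold lower number from compound 1 to compound 2 (0.14 log units; within the scatter) stays within the scatter. Compound 3 `COc1cc(OC)c(-c2coc3cc(OCc4ccccc4Br)ccc3c2=O)cc1OC` differs from compound 1 by 2-bromophenyl in place of vinyl on a saturated chain carbon bound to an oxygen on an aromatic ring. Going by the values given here, the single step that bears on this change likewise exchanged the vinyl for a substituted phenyl, and it moved the read-out only within the scatter. Compound 3 is therefore expected to show a 1.2-fold lower number from compound 1 to compound 3 (0.08 log units; within the scatter), nothing beyond the scatter. Compound 3 is estimated at 5500 nM, with a range from 2500 nM to 12000 nM.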

Compound 3, half-maximal inhibitory concentration: 4550 nM
The estimate for compound 3 lay 1.2-fold (0.08 log units) above the measured number; low and high end bracket the measured number.
By their numbers in this assay, from the lowest: compounds 3, 2 and 1 (each within the scatter of the next).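

Compound 3 adds a second substituted benzyl group at this position, and in this assay the exchange of allyl for 2-bromobenzyl (a 1.5-fold lower number from compound 1 to compound 3 (0.16 log units; within the scatter)) also stays within the scatter. The step that swaps trifluoromethyl for bromo on an aromatic carbon (a 1.0-fold lower number from compound 2 to compound 3 (0.02 log units; within the scatter)) is equally within the scatter, so these two groups cannot be told apart in this read-out. No supporting evidence is available to explain these results. On these data alone, whether an amine or a carboxylic acid on the benzyl ring would give a step beyond the scatter remains open. The same holds for a longer chain in place of allyl.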